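An Acetyl for a Methyl on a Weakly Active Scaffold

A few compounds are considered here, and "the series" means these few. Any claim that something is new, unique, unknown or untested is made for them only; others in the source may bear on it.

Compound 1, `Cc1cc(Nc2cc(Cl)cc(S(F)(F)(F)(F)F)c2)nc(N)n1`: > 180000 nM
Compound 2, `Cc1cc(Nc2cccc(Cl)c2)nc(N)n1`: > 180000 nM
Compound 3, `Cc1ccc(-c2cc(Cl)cc(Nc3cc(C)nc(N)n3)c2)cc1`: > 63000 nM

All three compounds were tested in an assay on cells for inhibition of S-adenosylmethionine decarboxylase proenzyme (Homo sapiens), read by mass spectrometry, at pH 7.2; on this read-out higher numbers stand for weaker inhibition and lower numbers for stronger inhibition. Compound 1 gave > 180000 nM, which is a limit of the assay rather than a number. Compound 2 likewise gave > 180000 nM, again a limit. Compound 3 stands at > 63000 nM, also a limit, so none of the three has a measured value and no one of them can be placed above or below the others.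

The steps among them carry no readable size: a step that the two limits leave unreadable from compound 1 to compound 2, a step that the two limits leave unreadable from compound 1 to compound 3 and a step that the two limits leave unreadable from compound 2 to compound 3 all fall between limits, as the evidence the limit of > 180000 nM in this assay, at which 2 of the 3 values shown sit, and the limit of > 63000 nM in this assay, at which 1 of the 3 values shown sits, shows.

Compound 4, `CC(=O)c1ccc(-c2cc(Cl)cc(Nc3cc(C)nc(N)n3)c2)cc1`, differs from compound 3 by acetyl in place of methyl on an aromatic carbon. For the measured compounds named here, no measured step touches this change, and the three steps that exist are unreadable, so nothing here points to a gain or loss in this assay. The expectation is therefore that compound 4 again returns a value near the limit, with the estimated step that the limit leaves unreadable from compound 3 to compound 4 resting only on the absence of any readable signal. For compound 4 the estimate is 100000 nM, within 20000 nM to 200000 nM, with a limit the most likely outcome.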

Compound 4, half-maximal inhibitory concentration: > 21000 nM
Compound 4: only a limit was reported (the forecaster's own chance of this, stated with the estimate: 75%); the middle value does not contradict the limit.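

In this assay compound 4 gives > 21000 nM, which is a limit of the assay and not a number. Compound 3 also has only a limit, so the step between compound 3 and compound 4 cannot be read. The compounds shown leave open whether any change to the shared core would give a measured value in this assay.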